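Phenoxyethyl ester to glycolate methyl ester: microsomal half-life

The source may hold more compounds than are shown below. What is called first, only, known or untested is meant among the compounds shown, and "the series" means these compounds.

Compound 1 `CCCOC(=O)/C=C/c1ccc(NC(=O)C2(NC(=O)c3ccc4c(C5CCCC5)c(-c5ncc(Cl)cn5)n(C)c4c3)CCC2)cc1OCC` — in an ADME assay (liver) for pharmacokinetics, with Liver microsome (Homo sapiens) as the target, using microsomes (on this read-out higher numbers stand for a longer-lived compound and lower numbers for a shorter-lived compound), compound 1 gives > 5 h, which is a limit of the assay and not a number.
Compound 2 `CCOc1cc(NC(=O)C2(NC(=O)c3ccc4c(C5CCCC5)c(-c5ncc(Cl)cn5)n(C)c4c3)CCC2)ccc1/C=C/C(=O)OCC(C)C` — in this assay compound 2 gives > 5 h, again a limit.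
Compound 3 `CCOc1cc(NC(=O)C2(NC(=O)c3ccc4c(C5CCCC5)c(-c5ncc(Cl)cn5)n(C)c4c3)CCC2)ccc1/C=C/C(=O)OCCOc1ccccc1` — in this assay compound 3 gives > 5 h, also a limit.

Compound 3 thus stands at the upper limit of this assay, and so do both other measured compounds, as the evidence shows: the limit of > 5 h in this assay, at which 3 of the 3 values shown sit. Because of this the steps between the measured compounds cannot be read for size: a step that the two limits leave unreadable from compound 1 to compound 2, a step that the two limits leave unreadable from compound 1 to compound 3 and a step that the two limits leave unreadable from compound 2 to compound 3.

Compound 4 `CCOc1cc(NC(=O)C2(NC(=O)c3ccc4c(C5CCCC5)c(-c5ncc(Cl)cn5)n(C)c4c3)CCC2)ccc1/C=C/C(=O)OCC(=O)OC` differs from compound 3 by methoxycarbonyl in place of phenoxymethyl on a saturated chain carbon bound to an oxygen next to a carbonyl group. Within the data shown here, no measured step bears on this change with a readable size, so the three measured compounds only show that the ester chains tried so far all reach the limit. For compound 4 the expected half-life is 3.5 h, with a range from 1.2 h to 8 h. This estimate corresponds to an at least 1.4-fold lower number from compound 3 to compound 4 (0.15 log units; that floor lies within the scatter), and a reading that is again only a limit is held to be quite possible.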

Compound 4, half-life: 2.1 h
Compound 4: the middle estimate sits 1.7-fold (0.22 log units) above what was measured, within the range that was stated.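

In this assay, compound 4 gives 2.1 h, and it alone among the four compounds shows a number rather than a limit, so the half-life does respond to the group on the saturated chain carbon bound to an oxygen next to a carbonyl group. Methoxycarbonyl in place of phenoxymethyl gives an at least 2.3-fold lower number from compound 3 to compound 4 (0.37 log units; beyond the scatter), methoxycarbonyl in place of isopropyl gives an at least 2.3-fold lower number from compound 2 to compound 4 (0.37 log units; beyond the scatter), and methoxycarbonyl in place of ethyl gives an at least 2.3-fold lower number from compound 1 to compound 4 (0.37 log units; beyond the scatter). Each of these steps has only a floor, and the steps among compound 1, compound 2 and compound 3 cannot be read: the limit of > 5 h in this assay, at which 3 of the 4 values shown sit.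

The compounds shown leave open how large these steps really are. They also leave open whether a carboxylic acid or an amine at this place would fall with compound 4 or stay at the limit.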